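Chloro on the pyridine Carbon of Compound 1

This account rests on a few compounds, and the source may have more. Where it says the series, first, only, none or still open, it means among the compounds named here.

Among the measured compounds shown here, compound 1 `CN1CCC[C@H]1COc1cccnc1` gives, in an assay on K177 cells with Neuronal acetylcholine receptor; alpha4/beta2 (Homo sapiens) as the target (a lower number here means a smaller maximal response, a higher number a larger maximal response), 100%, the higher of the two numbers measured so far. Compound 2 `Cc1cncc(OC[C@@H]2CCCN2C)c1`, which carries a methyl in place of hydrogen on an aromatic carbon, gives 77%; the step of a number 23 percentage points lower from compound 1 to compound 2 (beyond the scatter) is modest but beyond the scatter. Compound 3 `CN1CCC[C@H]1COc1ccc(Cl)nc1` is not yet measured. It differs from compound 1 by chloro in place of hydrogen on an aromatic carbon. For the measured compounds named here, the only measured step that bears on this change is the one from compound 1 to compound 2, where a single substituent was added on an aromatic carbon of the same ring and the maximal response fell by a modest amount. Compound 3 is therefore expected to show a comparable modest decrease, a number 16 percentage points lower from compound 1 to compound 3 (beyond the scatter), and compound 3 is estimated at 84%, within a range from 60% to 105%.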

Compound 3, largest response reached (reported as maximum), in percent of the reference or control that the assay uses: 108%
The estimate for compound 3 lay 24 percentage points below the measured number, and the stated range ends below it.
By their numbers in this assay, from the lowest: compound 2; then compounds 1 and 3 (each within the scatter of the next).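

In this assay, chloro on the aromatic carbon next to the ring nitrogen, para to a group of 8 heavy atoms, leaves the maximal response indistinguishable from that of the unsubstituted parent, a number 8 percentage points higher from compound 1 to compound 3 (within the scatter). A substituent on this ring therefore need not cost response, as the methyl step, a number 23 percentage points lower from compound 1 to compound 2 (beyond the scatter), alone might have suggested, although that step changes both the group and its place and so cannot separate the two. Nothing available here explains why the response is retained at this position.

As far as these compounds go, it remains open whether methyl on this same carbon would retain the response as chloro does, or would lower it as in compound 2. Equally open, from the compounds shown here alone, is how bromo, methoxy or an amine would behave at this position.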